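A Methoxy Added at the Far Phenyl Ring

The compounds below may be only part of what the source reports. "The series", "measured", "known", "first", "only" and "open" are said of these compounds alone.

Compound 1 `COc1cc(/C=C/C(=O)c2cccc(-n3cc(-c4ccccc4)[nH]c3=O)c2)ccc1O`: 2210 nM
Compound 2 `O=C(/C=C/c1cccc(O)c1)c1cccc(-n2cc(-c3ccccc3)[nH]c2=O)c1`: 2010 nM
Compound 3 `COc1cc(/C=C/C(=O)c2cccc(-n3cc(-c4ccccc4)[nH]c3=O)c2)cc(OC)c1OC`: 1510 nM

The three measured compounds share one core and differ only in the ring at the end of the double-bonded chain. In a functional assay on COLO 205 cells (Homo sapiens) for inhibition (a higher number here means a weaker inhibitor of growth, a lower number a stronger inhibitor of growth), compound 3 sits at the low end of this narrow set, yet its distances to compound 2 and compound 1 both fall within the scatter, so the three cannot be told apart. Among the compounds with values here, the one measured step, a 1.1-fold lower number from compound 1 to compound 2 (0.04 log units; within the scatter), is also within the scatter. Compound 4 `COc1ccc(-c2cn(-c3cccc(C(=O)/C=C/c4cc(OC)c(OC)c(OC)c4)c3)c(=O)[nH]2)cc1` differs from compound 3 in a single place: methoxy in place of hydrogen on an aromatic carbon. Within the data shown here, no measured step touches that ring, so nothing here argues for a shift in either direction beyond the scatter. Compound 4 is therefore expected at 1500 nM, within 500 nM to 4500 nM, which amounts to an estimated 1.0-fold lower number from compound 3 to compound 4 (0.00 log units; within the scatter).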

Compound 4, concentration for 50% growth inhibition: 1840 nM
The estimate for compound 4 lay 1.2-fold (0.09 log units) below the measured number; the range from low to high includes it.
By their numbers in this assay, from the lowest: compounds 3, 4, 2 and 1 (each within the scatter of the next).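

Earlier steps touched only the ring on the double-bonded chain; this one changes the other phenyl, at an aromatic carbon para to a large group. In this assay the change from phenyl to 4-methoxyphenyl gives a 1.2-fold higher number from compound 3 to compound 4 (0.09 log units; within the scatter) and so shows that this carbon can carry a methoxy with no shift that can be told from the scatter. Nothing further is at hand that bears on this result. As far as these compounds go, whether an amine, a carboxylic acid or a longer chain on this same carbon would move the number beyond the scatter stays open.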